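The compounds below may be only part of what the source reports. "The series", "measured", "known", "first", "only" and "open" are said of these compounds alone.

Compound 3, `CC(C)(C)c1cc(NC(=O)[C@@H]2CCCCN2C(=O)c2ccc(Cl)cc2)no1`, stands highest of the three compounds measured in an ADME assay (liver) for metabolic stability, with Liver microsome (Homo sapiens) as the target, read by LC-MS, using microsomes and NADPH, tested at 1 uM (a higher number here means that the compound lasts longer, a lower number that the compound disappears faster), with a half-life of 1.25 h. Its nearest neighbour on the numbers is compound 2, `CC(C)(C)c1cc(NC(=O)[C@@H]2CCCCN2C2CCOCC2)no1`, which in this assay gives 0.317 h, and the lowest is compound 1, `CC(C)CN1CCCC[C@H]1C(=O)Nc1cc(C(C)(C)C)on1`, which gives 0.1 h. The steps between them are all at the amine nitrogen of the ring: a 3.2-fold higher number from compound 1 to compound 2 (0.50 log units; beyond the scatter), a 3.9-fold higher number from compound 2 to compound 3 (0.60 log units; beyond the scatter), and a 13-fold higher number from compound 1 to compound 3 (1.10 log units; beyond the scatter).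

Compound 4, `CC(C)(C)c1cc(NC(=O)[C@@H]2CCCCN2C(=O)C2CCCCC2)no1`, keeps the carbonyl on that ring nitrogen and differs from compound 3 only in the group on that carbonyl carbon: cyclohexyl in place of 4-chlorophenyl on a carbonyl carbon.

None of the three measured steps touches the carbonyl carbon; all three replace the whole group on the ring nitrogen, and the two that brought in the (4-chlorophenyl)carbonyl were the modest and the large step. They show that the carbonyl on the ring nitrogen went with the higher numbers, but they say nothing about swapping one ring for another on that carbonyl carbon. The expected step in this assay is therefore small, likely at the edge of the scatter, and if anything downward: a 1.8-fold lower number from compound 3 to compound 4 (0.25 log units; within the scatter). Compound 4 is accordingly estimated to give 0.7 h in this assay, in a range from 0.3 h to 1.6 h.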

Compound 4, half-life in the Liver microsome assay: 0.483 h
Beside the measured number, compound 4's estimate is 1.4-fold (0.16 log units) above it; measured number inside the range.
By their numbers in the Liver microsome assay, from the lowest: compound 1; then compounds 2 and 4 (each within the scatter of the next); then compound 3.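

Within the data shown here, this is the first change made on the carbonyl carbon itself rather than of the whole group on the ring nitrogen, and in the Liver microsome assay it gives a 2.6-fold lower number from compound 3 to compound 4 (0.41 log units; beyond the scatter), so the group on that carbon counts as well as the carbonyl; against the other two compounds the cyclohexylcarbonyl gives a 1.5-fold higher number from compound 2 to compound 4 (0.18 log units; within the scatter) and a 4.8-fold higher number from compound 1 to compound 4 (0.68 log units; beyond the scatter), and the first of these shows that a carbonyl on the ring nitrogen does not by itself separate a compound from the oxan-4-yl compound. In a physicochemical assay for solubility, read by HPLC, at pH 6.8 (on this read-out higher numbers stand for higher solubility and lower numbers for lower solubility), the same change gives an at least 64-fold higher number from compound 3 to compound 4 (1.80 log units; beyond the scatter), the opposite direction to the step in half-life. In the physicochemical assay compound 4 gives 6.4 ug/mL. In the physicochemical assay compound 3 gives < 0.1 ug/mL, which is a limit of the assay and not a number, so the size of that step is itself only a limit: the limit of < 0.1 ug/mL in the physicochemical assay, at which 1 of the 2 values shown sits.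

The change removes the chlorine and the aromatic ring together, so the compounds shown do not tell which of the two goes with either step, and an unsubstituted phenyl on the carbonyl carbon would separate them. From the compounds shown here alone, how a smaller group such as methyl, or a hydroxyl on the cyclohexyl, would stand in either read-out also stays open.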